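The source may hold more compounds than are shown below. What is called first, only, known or untested is meant among the compounds shown, and "the series" means these compounds.

Working notes on an ADME assay on BJ cells (Homo sapiens) for cytotoxicity, read by CellTiter-Glo and resazurin assay, with a stated time of 72 h; on this read-out higher numbers stand for an effect only at larger amounts of compound and lower numbers for an effect already at smaller amounts. Compound 1 `COc1cc(F)cc(-c2ccc(C(=O)N(Cc3cccc(OCCCCCC(=O)O)c3)C(C)C)cc2)c1` opens the set. In this assay compound 1 gives > 26000 nM, which is a limit of the assay and not a number. Compound 2 `COc1ccc(F)c(-c2ccc(C(=O)N(Cc3cccc(OCCCCCC(=O)O)c3)C(C)C)cc2)c1` differs from compound 1 by 2-fluoro-5-methoxyphenyl in place of 3-fluoro-5-methoxyphenyl on an aromatic carbon. In this assay compound 2 gives > 26000 nM, again a limit. The step that the two limits leave unreadable from compound 1 to compound 2 therefore has no readable size. Compound 3 `CCOC(=O)CCCCCOc1cccc(CN(C(=O)c2ccc(-c3cc(F)cc(OC)c3)cc2)C(C)C)c1` differs from compound 1 by ethyl in place of hydrogen on an oxygen next to a carbonyl group. In this assay compound 3 gives > 26000 nM, likewise a limit. The step that the two limits leave unreadable from compound 1 to compound 3 is equally unreadable. All three values sit at the limit of > 26000 nM in this assay, at which 3 of the 3 values shown sit, so nothing yet separates any of them. Compound 4 `CCOC(=O)CCCCCOc1cccc(CN(C(=O)c2ccc(-c3cc(OC)ccc3F)cc2)C(C)C)c1` is not yet measured; it differs from compound 3 by 2-fluoro-5-methoxyphenyl in place of 3-fluoro-5-methoxyphenyl on an aromatic carbon, the same change as from compound 1 to compound 2, with the place described in the same words, while the two cores differ by ethyl in place of hydrogen on an oxygen next to a carbonyl group. Beside that earlier unreadable step, the step that the limit leaves unreadable from compound 3 to compound 4 for compound 4 is expected to be small, because the change has nowhere moved a value off the limit (the limit of > 26000 nM in this assay, at which 3 of the 3 values shown sit). Compound 4 is expected to give about 40000 nM, between 20000 nM and 100000 nM, and most probably only a limit is reported again.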

Compound 4, half-maximal effective concentration: > 26000 nM
Compound 4: no number, only a limit; the forecaster's own chance of this, stated with the estimate: 85%; the middle value does not contradict the limit.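

In this assay compound 4 gives > 26000 nM, a limit of the assay and not a number. No new step can be read from compound 4 to either compound 2 or compound 3, as all values stay at one limit: the limit of > 26000 nM in this assay, at which 4 of the 4 values shown sit.

The compounds shown leave open whether 2-fluoro-5-methoxyphenyl in place of 3-fluoro-5-methoxyphenyl, or ethyl in place of hydrogen, changes this read-out at all.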